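Aminobenzamide series: hydroxy to methoxy on the aniline ring

A few compounds are considered here, and "the series" means these few. Any claim that something is new, unique, unknown or untested is made for them only; others in the source may bear on it.

Measured compounds:
compound 1, `Nc1ccccc1NC(=O)c1ccc(CNC2=N[C@@H](Cc3ccccc3)CS2)cc1`, 34900 nM
compound 2, `Nc1cc(O)ccc1NC(=O)c1ccc(CNc2nccc(-c3cccnc3)n2)cc1`, > 20000 nM
compound 3, `CC(C)(C)OC(=O)N1C(NCc2ccc(C(=O)Nc3ccccc3N)cc2)=NC(=O)C1Cc1c[nH]c2ccccc12`, 27200 nM

In an assay for inhibition of histone deacetylase 8 (Homo sapiens), read by fluorescence, with stated times of 15 min and 60 min (on this read-out higher numbers stand for weaker inhibition and lower numbers for stronger inhibition), compound 1 gives 34900 nM and compound 3 gives 27200 nM. For compound 2 only a limit is reported, > 20000 nM, which is the limit of > 20000 nM in this assay, at which 1 of the 3 values shown sits. Compound 4, `COc1ccc(NC(=O)c2ccc(CNc3nccc(-c4cccnc4)n3)cc2)c(N)c1`, differs from compound 2 by methyl in place of hydrogen on an oxygen on an aromatic ring. Among the measured compounds shown here, no step between two measured compounds is available to size this change. The expectation is that the step from compound 2 to compound 4 is none beyond the scatter, a step that the limit leaves unreadable from compound 2 to compound 4. Compound 4 is therefore estimated at 30000 nM, with a range from 12000 nM to 80000 nM, and a limit rather than a number is likely.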

Compound 4, half-maximal inhibitory concentration: > 20000 nM
Compound 4: no number, only a limit; the forecaster's own chance of this, stated with the estimate: 55%; the middle value does not contradict the limit.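

No step can be read from compound 2 to compound 4, as both are reported in this assay only as limits and not as numbers. The compounds shown leave open whether hydroxy to methoxy changes inhibition at all.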